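The compounds below may be only part of what the source reports. "The series", "measured", "known", "first", "only" and "open" are said of these compounds alone.

In an ADME assay on MT4 cells (Homo sapiens) for cytotoxicity, read by MTT assay (on this read-out lower numbers stand for higher toxicity in this test and higher numbers for lower toxicity in this test), the measured members of this small series all lie toward the less toxic end of the scale. Compound 1 `S=C(Nc1ccccc1)OCCc1ccccn1` returns only a limit in this assay, > 100000 nM, which is the limit of > 100000 nM in this assay, at which 1 of the 3 values shown sits, so its true position on the scale is not known. Compound 2 `CCc1ccc(NC(=S)OCCc2ccccn2)cc1`, bearing an ethyl group on an aromatic carbon, gives 44000 nM in this assay, and compound 3 `S=C(Nc1ccc(Cl)cc1)OCCc1ccccn1`, bearing a chloro group on an aromatic carbon, gives 52000 nM. The two substituted compounds sit close together, with a 1.2-fold higher number from compound 2 to compound 3 (0.07 log units; within the scatter), while each of them moves away from the parent: an at least 2.2-fold lower number from compound 1 to compound 2 (0.35 log units; beyond the scatter) and an at least 1.9-fold lower number from compound 1 to compound 3 (0.28 log units; that floor lies within the scatter), the second floor resting within the scatter.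

Compound 4 `CN(C)c1ccc(NC(=S)OCCc2ccccn2)cc1` differs from compound 1 by dimethylamino in place of hydrogen on an aromatic carbon. The steps from compound 1 to compound 2 and from compound 1 to compound 3 are the ones that bear on this change, since each places a small group on the same kind of aromatic carbon, and both brought the number down by at least a modest amount. Compound 4 is therefore expected to follow the same course, with an estimated at least 2.0-fold lower number from compound 1 to compound 4 (0.30 log units; that floor lies within the scatter). The value expected for compound 4 in this assay is 50000 nM, in a range from 20000 nM to 150000 nM.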

Compound 4, half-maximal cytotoxic concentration: 60000 nM
Compound 4: the middle estimate sits 1.2-fold (0.08 log units) below what was measured; the measured number falls inside the stated range.
By their numbers in this assay, from the lowest: compounds 2, 3 and 4 (each within the scatter of the next). At a limit, above all of these: compound 1.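

With dimethylamino on this aromatic carbon, para to a large group, the series now holds a substituent carrying nitrogen and a hydrogen-bond acceptor, yet in this assay compound 4 cannot be told apart from the ethyl and chloro compounds: a 1.2-fold higher number from compound 3 to compound 4 (0.06 log units; within the scatter) and a 1.4-fold higher number from compound 2 to compound 4 (0.13 log units; within the scatter). Among these three compounds, then, the change of group at this position leaves no difference that rises beyond the scatter, even though the entering groups differ in their atoms. The step to the parent is less firm, with an at least 1.6-fold lower number from compound 1 to compound 4 (0.22 log units; that floor lies within the scatter), so this change alone does not establish a separation from compound 1, whose entry in this series is only a limit: the limit of > 100000 nM in this assay, at which 1 of the 4 values shown sits.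

As far as these compounds go, how far the three substituted compounds truly lie from compound 1 therefore remains open, as does the question of whether dimethylamino would give a similar number on another aromatic carbon of the ring. From the compounds shown here alone, it is also open whether a carboxylic acid, a primary amine or a longer alkyl chain on this same carbon would stay with compounds 2, 3 and 4 or move away from them.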